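The compounds below may be only part of what the source reports. "The series", "measured", "known", "first", "only" and "open" are said of these compounds alone.

Compound 1 `Cc1ccc2c(O)c(Cc3ccccc3)cnc2n1` and compound 2 `Cc1ccc2c(O)c(C(=O)NN3CCOCC3)cnc2n1` carry the same core. In an assay for binding affinity to adenosine receptor A1 (Bos taurus) (a higher number here means a weaker inhibitor, a lower number a stronger inhibitor), compound 1 gives only a limit of the assay, > 10000 nM. In this assay compound 2 likewise gives only a limit, > 10000 nM. Compound 2 therefore stands at the edge of what this assay reports, as the limit of > 10000 nM in this assay, at which 2 of the 2 values shown sit, shows. Compound 3 `Cc1ccc2c(O)c(C(=O)NC3CCC(C)CC3)cnc2n1` differs from compound 2 by 4-methylcyclohexyl in place of morpholin-4-yl on an amide-type nitrogen. Within the data shown here, with no measured step to go by, no change beyond the scatter is expected in this assay. Compound 3 is expected to come out near 20000 nM, within 7000 nM to 60000 nM. The estimate amounts to an expected step that the limit leaves unreadable from compound 2 to compound 3.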

Compound 3, inhibition constant: 6000 nM
Compound 3: middle estimate off by 3.3-fold (0.52 log units), on the high side; the whole stated range lies above it.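

With 4-methylcyclohexyl on the amide-type nitrogen, compound 3 alone of the three compounds gives a number rather than a limit in this assay, so a measurable value is reached at this position. Replacing morpholin-4-yl amounts to an at least 1.6-fold lower number from compound 2 to compound 3 (0.22 log units; that floor lies within the scatter), which leaves the true size of the change unfixed. Compound 2 remains at a limit of the assay: the limit of > 10000 nM in this assay, at which 2 of the 3 values shown sit. On these data alone, whether the methyl group matters remains open, as an unsubstituted cyclohexyl would show. So does whether a phenyl or a longer alkyl chain on this nitrogen would give a lower number.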